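Working notes: methoxy in place of ethyl

A few compounds are considered here, and "the series" means these few. Any claim that something is new, unique, unknown or untested is made for them only; others in the source may bear on it.

compound 1 `CC(C)Oc1cc(Oc2ccc(S(C)(=O)=O)cc2)cc(-c2cncc(=O)[nH]2)c1` gives 2.27
compound 2 `CC(C)Oc1cc(Oc2ccc(S(C)(=O)=O)cc2)cc(-c2nccc(=O)[nH]2)c1` gives 2.14
compound 3 `CCc1cnc(-c2cc(Oc3ccc(S(C)(=O)=O)cc3)cc(OC(C)C)c2)[nH]c1=O` gives 3.11

In a physicochemical assay for lipophilicity, using the shake flask method (on this read-out higher numbers stand for higher lipophilicity and lower numbers for lower lipophilicity), compound 3 at 3.11 stands highest of the three, with its steps to both others beyond the scatter. Compound 4 `COc1cnc(-c2cc(Oc3ccc(S(C)(=O)=O)cc3)cc(OC(C)C)c2)[nH]c1=O` has not yet been measured. It differs from compound 3 by methoxy in place of ethyl on an aromatic carbon and in words this is methoxy in place of ethyl on an aromatic carbon. Within the data shown here, the one measured step at this place is ethyl in place of hydrogen, a number 0.97 log units higher from compound 2 to compound 3 (beyond the scatter) and no measured compound carries methoxy. A fall most of the way back towards compound 2 at 2.14 is therefore expected, with wide uncertainty. In this assay the expected step is a number 0.76 log units lower from compound 3 to compound 4 (beyond the scatter) and it would lie beyond the scatter. For compound 4 the estimate is 2.35 in a range from 1.95 to 2.75 for the measurement.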

Compound 4, distribution coefficient: 2.21
Compound 4: the middle estimate sits 0.14 log units above what was measured; the measured number falls inside the stated range.
By their numbers in this assay, from the lowest: compounds 2, 4 and 1 (each within the scatter of the next); then compound 3.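

In this assay the two groups at this position are not interchangeable: methoxy in place of ethyl gives a number 0.90 log units lower from compound 3 to compound 4 (beyond the scatter) and takes away the rise seen with ethyl. Methoxy in place of hydrogen gives a number 0.07 log units higher from compound 2 to compound 4 (within the scatter) and the other comparison gives a number 0.06 log units lower from compound 1 to compound 4 (within the scatter) so, of the groups shown here, only ethyl stands apart. Nothing in hand accounts for the difference between ethyl and methoxy.

As far as these compounds go, whether a longer chain such as propyl follows ethyl, or an amine follows methoxy, stays open at this place. From the compounds shown here alone, whether these steps hold with other groups on the shared core also stays open.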